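A few compounds are considered here, and "the series" means these few. Any claim that something is new, unique, unknown or untested is made for them only; others in the source may bear on it.

Compound 1, with the structure `CCCn1c(=O)[nH]c2nc(-c3ccc(S(=O)(=O)N4CCN(c5ccc(Br)cc5)CC4)cc3)[nH]c2c1=O`, carries a 4-bromophenyl on an amine nitrogen in a ring. In an assay on CHO cells for displacement of a labelled ligand from adenosine receptor A3 (Homo sapiens), read by scintillation counting, with a stated time of 45 min, in the presence of a further agent that is not named here (on this read-out higher numbers stand for weaker inhibition and lower numbers for stronger inhibition), compound 1 gives only a limit, > 1000 nM, and no number. Its two neighbours sit the same way. Compound 2, `CCCn1c(=O)[nH]c2nc(-c3ccc(S(=O)(=O)N4CCN(c5ccc(Cl)cc5F)CC4)cc3)[nH]c2c1=O`, with a 4-chloro-2-fluorophenyl in the same place, gives in this assay a limit of > 1000 nM. Compound 3, `CCCn1c(=O)[nH]c2nc(-c3ccc(S(=O)(=O)N4CCN(Cc5cccc(C)c5)CC4)cc3)[nH]c2c1=O`, which bears a 3-methylbenzyl there, likewise returns a limit of > 1000 nM. Each step among these three is therefore of unreadable size: a step that the two limits leave unreadable from compound 1 to compound 2, a step that the two limits leave unreadable from compound 1 to compound 3 and a step that the two limits leave unreadable from compound 2 to compound 3 all lie between two limits, and the limit of > 1000 nM in this assay, at which 3 of the 3 values shown sit, is the whole of the evidence the set offers.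

Compound 4, `CCCn1c(=O)[nH]c2nc(-c3ccc(S(=O)(=O)N4CCN(c5ccc(C)cc5)CC4)cc3)[nH]c2c1=O`, differs from compound 1 by methyl in place of bromo on an aromatic carbon. For the measured compounds named here, no measured step among the three compounds bears on this change in a readable way, and every value so far stands at the limit. Compound 4 is therefore expected to remain weak in this assay, with an estimated value of 3000 nM in a range of 700 nM to 20000 nM, which corresponds to an expected step that the limit leaves unreadable from compound 1 to compound 4 that most likely will again be reported only as a limit.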

Compound 4, inhibition constant: > 1000 nM
Compound 4: a limit, no number; the forecaster's own chance of this, stated with the estimate: 80%; the middle value lies beyond the limit too.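

In this assay compound 4 also gives only a limit, > 1000 nM, and no number, so its steps from compound 1, compound 2 and compound 3 cannot be read. The compounds shown leave open how any of these groups on the amine nitrogen in the ring affects the inhibition constant, on which the set offers only this: the limit of > 1000 nM in this assay, at which 4 of the 4 values shown sit.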